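Working notes: aryl group variation on the ring nitrogen

The compounds below may be only part of what the source reports. "The series", "measured", "known", "first", "only" and "open" are said of these compounds alone.

Measured so far:
Compound 1 `O=C1c2ccccc2S(=O)(=O)N1CCCCCCN1CCN(c2cccc(Cl)c2Cl)CC1`: 920 nM
Compound 2 `O=C1c2ccccc2S(=O)(=O)N1CCCCCCN1CCN(c2ccccc2C(F)(F)F)CC1`: 1270 nM

In an ADME assay on HEK293 cells for displacement of a labelled ligand from 5-hydroxytryptamine receptor 6 (Homo sapiens), read by radioligand binding, with a stated time of 1 h (on this read-out higher numbers stand for weaker inhibition and lower numbers for stronger inhibition), compound 1 gives 920 nM, the lowest of the two numbers. Compound 2 gives 1270 nM; the step of a 1.4-fold higher number from compound 1 to compound 2 (0.14 log units; within the scatter) swaps one substituted ring for another and stays within the scatter.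

Compound 3 `O=C1c2ccccc2S(=O)(=O)N1CCCCCCN1CCN(c2ccccc2)CC1` is unmeasured. Change from compound 1: phenyl in place of 2,3-dichlorophenyl on an amine nitrogen in a ring. Among the measured compounds shown here, the only measured step, a 1.4-fold higher number from compound 1 to compound 2 (0.14 log units; within the scatter), keeps ring substituents; none removes them outright, so guidance is thin. A small weakening step is expected, a 1.7-fold higher number from compound 1 to compound 3 (0.24 log units; within the scatter), with wide uncertainty. Compound 3 is estimated at 1600 nM, range 500 nM to 5000 nM.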

Compound 3, inhibition constant: 971 nM
The estimate for compound 3 lay 1.6-fold (0.22 log units) above the measured number; the measured number falls inside the stated range.
By their numbers in this assay, from the lowest: compounds 1, 3 and 2 (each within the scatter of the next).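

In this assay, the bare ring settles what the earlier pair could not: phenyl in place of 2,3-dichlorophenyl on the amine nitrogen in the ring gives a step within the scatter (a 1.1-fold higher number from compound 1 to compound 3 (0.02 log units; within the scatter)). Hydrogen in place of trifluoromethyl on an aromatic carbon does the same (a 1.3-fold lower number from compound 2 to compound 3 (0.12 log units; within the scatter)). Substituents are thus not required at this position for numbers of this size, and no measurement on hand accounts for this.

All three aryl groups remain within the scatter of one another, so no group yet shows a real difference at this position. On these data alone, the effects of a methoxy group or nitrile on the phenyl, a pyridine in its place, or a shorter chain remain open.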